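The source may hold more compounds than are shown below. What is called first, only, known or untested is meant among the compounds shown, and "the series" means these compounds.

Three compounds have so far been measured in a functional assay on UACC-257 cells (Homo sapiens) for inhibition, read by sulforhodamine B assay, with a stated time of 48 h; a higher number here means a weaker inhibitor of growth, a lower number a stronger inhibitor of growth:

Compound 1 `Nc1cc(N)c2nc(-c3ccccc3)c(Oc3ccc(Cl)c(Cl)c3)nc2c1` gives 28200 nM.
Compound 2 `CCOC(=O)[C@H](CCC(=O)O)NC(=O)c1ccc(Sc2nc3cc(N)cc(N)c3nc2-c2ccccc2)cc1` gives 17400 nM.
Compound 3 `CCOC(=O)[C@H](CCC(=O)O)NC(=O)c1ccc(Oc2nc3cc(N)cc(N)c3nc2-c2ccccc2)cc1` gives 26900 nM.

All three share the same core and differ only in the group attached to it. Compound 1 has the highest number of the three, but this says little: compound 3 sits closest to it and compound 2 furthest away, and both of those gaps lie within the scatter of repeated measurements. On the evidence shown, the three compounds cannot be told apart in this assay.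

The step of interest leads from compound 1 to compound 4 `COc1ccc(Sc2nc3cc(N)cc(N)c3nc2-c2ccccc2)cc1`, which has not yet been measured. The change is (4-methoxyphenyl)sulfanyl in place of 3,4-dichlorophenoxy on an aromatic carbon. Compound 2 and compound 3 show that replacing an oxygen link by a sulfur link of the same kind, with the same partner, left the number within the scatter. For the measured compounds named here, there is no measured pair that isolates the change from 3,4-dichlorophenoxy to (4-methoxyphenyl)sulfanyl, so no step size beyond the scatter can be anticipated in either direction in this assay.

Compound 4 is therefore expected to give about 18000 nM in this assay, within a range of 6000 nM to 50000 nM. This estimate means a step of a 1.6-fold lower number from compound 1 to compound 4 (0.19 log units; within the scatter), expected to stay inside the scatter.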

Compound 4, concentration for 50% growth inhibition: 43700 nM
The estimate for compound 4 lay 2.4-fold (0.39 log units) below the measured number; measured number inside the range.
By their numbers in this assay, from the lowest: compounds 2, 3, 1 and 4 (each within the scatter of the next, the first and the last beyond it).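

In this assay, placing (4-methoxyphenyl)sulfanyl instead of 3,4-dichlorophenoxy on this aromatic carbon, next to the ring nitrogen and ortho to a phenyl group, gives a 1.5-fold higher number from compound 1 to compound 4 (0.19 log units; within the scatter), so the two compounds cannot be told apart. This pair adds something that compounds 2 and 3 could not show: the linking atom and the substituents on the attached benzene ring can change together at this position, with the heavy-atom count of the group unchanged, and the number still stays within the usual scatter of the measurement. Nothing measured here offers an explanation for the size of this step.

Since both features change at once, the separate contributions of the sulfur link, the methoxy group and the two chlorines remain unresolved, and 3,4-dichlorophenylsulfanyl and 4-methoxyphenoxy would be the groups that could pull them apart. From the compounds shown here alone, it also remains open how this carbon would respond to a group of a different kind, such as an amine or a longer alkyl chain in place of the linked benzene ring.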